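This account rests on a few compounds, and the source may have more. Where it says the series, first, only, none or still open, it means among the compounds named here.

Measured so far in a functional assay on ileum for antagonist activity at muscarinic acetylcholine receptor M3 (Cavia porcellus); a lower number here means a stronger inhibitor, a higher number a weaker inhibitor:
- compound 1, `COc1ccccc1N1CCN(CC(=O)C(O)(c2ccccc2)C2CCC2)CC1`: > 10000 nM
- compound 2, `O=C(CN1CCC(N2CCCC2)CC1)C(O)(c1ccccc1)C1CCC1`: > 10000 nM
- compound 3, `O=C(CN1CCN(Cc2cccs2)CC1)C(O)(c1ccccc1)C1CCC1`: 43.8 nM

Compound 2 gives only a limit of the assay, > 10000 nM, and no number. It shares that limit with compound 1, since (the limit of > 10000 nM in this assay, at which 2 of the 3 values shown sit). For the measured compounds named here, the one measured step, an at least 220-fold lower number from compound 1 to compound 3 (2.35 log units; beyond the scatter), changes the group on the ring amine nitrogen and so does not touch the change now in question. Compound 4, `O=C(CN1CCC(N2CCCC2)CC1)C(O)(c1ccccc1)C1CCCCC1`, differs from compound 2 only by cyclohexyl in place of cyclobutyl on a saturated chain carbon bound to an aromatic carbon, a carbonyl carbon and an oxygen on a saturated carbon. Going by the values given here, no measured step covers a change of that kind, so the expectation rests on the limit alone. From compound 2 the step of an at least 2.0-fold lower number from compound 2 to compound 4 (0.30 log units; that floor lies within the scatter) is expected in this assay. Compound 4 is therefore estimated at 5000 nM, within 500 nM to 30000 nM.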

Compound 4, antagonist equilibrium constant: 349 nM
Compound 4: middle estimate off by 14-fold (1.16 log units), on the high side, outside the stated range (below it).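

In this assay cyclohexyl in place of cyclobutyl gives an at least 28-fold lower number from compound 2 to compound 4 (1.45 log units; beyond the scatter) and so shows that this position, and not only the ring amine nitrogen, can move the number by a large step. The true step may be larger still, since compound 2 gives only a limit: the limit of > 10000 nM in this assay, at which 2 of the 4 values shown sit.

Still open, as far as these compounds go, is how a cyclopentyl group or an open-chain isopropyl group would fare at this position. Also open, from the compounds shown here alone, is whether the same change would give a similar step with the (thiophen-2-yl)methyl group of compound 3 on the ring amine nitrogen.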